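The source may hold more compounds than are shown below. What is called first, only, known or untested is meant among the compounds shown, and "the series" means these compounds.

Compound 1 `COc1ncc(-c2ccc3c(c2)N(c2ccc(C)cc2)C(=O)CO3)cc1NS(=O)(=O)c1ccc(F)cc1`: 22700 nM
Compound 2 `COc1cccc(N2C(=O)COc3ccc(-c4cnc(Cl)c(NS(=O)(=O)c5ccc(F)cc5)c4)cc32)c1`: > 40000 nM

Both compounds were tested in a functional assay on HCT-116 cells (Homo sapiens) for antiproliferative activity, read by MTT assay, with a stated time of 72 h; a higher number here means a weaker inhibitor, a lower number a stronger inhibitor. Compound 1 gives a measured number, 22700 nM. For compound 2 the assay reports only a limit, not a number, as shown in the limit of > 40000 nM in this assay, at which 1 of the 2 values shown sits. Compound 2 therefore stands at the weak end of the two values shown, and how far beyond that edge it lies cannot be read from the data.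

Compound 3 `O=C1COc2ccc(-c3cnc(Cl)c(NS(=O)(=O)c4ccc(F)cc4)c3)cc2N1C1CCCCC1` has not yet been tested. It is compound 2 with a single exchange: cyclohexyl in place of 3-methoxyphenyl on an amide-type nitrogen in a ring. Within the data shown here, no pair of measured compounds here differs in only one place, so there is no measured step to say how such an exchange moves the read-out. The expectation for the step from compound 2 to compound 3 is none beyond the scatter, so compound 3 is expected to remain at or near the limit, which is what the estimated step that the limit leaves unreadable from compound 2 to compound 3 expresses. Compound 3 is estimated at 45000 nM, with a range from 15000 nM to 150000 nM, and with a good chance that this assay again reports only a limit.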

Compound 3, half-maximal inhibitory concentration: > 40000 nM
Compound 3 gave a limit, no number (the forecaster's own chance of this, stated with the estimate: 60%); the middle value does not contradict the limit.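

Compound 2 and compound 3 both give only a limit rather than a number, so no step between them can be read: the limit of > 40000 nM in this assay, at which 2 of the 3 values shown sit.

The compounds shown leave open how far past that limit each one lies, and whether cyclohexyl in place of 3-methoxyphenyl changes the antiproliferative activity at all.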